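Cyclopropyl aryl swap: difluorophenyl to pyridin-3-yl

The source may report more compounds than this note shows. Statements on the series, on what has been measured and on what is new or still open speak of the compounds shown alone.

In a functional assay for agonist activity at G protein-coupled receptor 88 (Homo sapiens), read by HTRF and cAMP accumulation; on this read-out higher numbers stand for an effect only at larger amounts of compound and lower numbers for an effect already at smaller amounts:
compound 1 `CC[C@H](C)[C@H](N)CN(C(=O)[C@@H]1C[C@H]1c1cc(F)ccc1F)c1ccc(-c2ccccc2)cc1`: 770 nM
compound 2 `CC[C@H](C)[C@H](N)CN(C(=O)[C@@H]1C[C@H]1c1ccc(F)c(F)c1)c1ccc(-c2ccccc2)cc1`: 720 nM

Compound 2 holds the lowest of the two numbers, and compound 1 sits within the scatter of it: a 1.1-fold lower number from compound 1 to compound 2 (0.03 log units; within the scatter). Compound 3 `CC[C@H](C)[C@H](N)CN(C(=O)[C@@H]1C[C@H]1c1cccnc1)c1ccc(-c2ccccc2)cc1` differs from compound 2 by pyridin-3-yl in place of 3,4-difluorophenyl on a saturated ring carbon. Going by the values given here, the single measured step exchanges one difluorophenyl for another on the same saturated ring carbon and stays within the scatter; no measured step replaces a carbon-only ring by a ring with one hetero atom, so direction and size remain open. The step is expected to be a 1.4-fold higher number from compound 2 to compound 3 (0.14 log units; within the scatter), around no change but with wide uncertainty. Compound 3 is estimated at 1000 nM, range 350 nM to 3500 nM.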

Compound 3, half-maximal effective concentration: 1500 nM
Beside the measured number, compound 3's estimate is 1.5-fold (0.18 log units) below it, within the range that was stated.
By their numbers in this assay, from the lowest: compounds 2, 1 and 3 (each within the scatter of the next, the first and the last beyond it).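

In this assay, the aryl group on this saturated ring carbon gives its first step beyond the scatter, with a 2.1-fold higher number from compound 2 to compound 3 (0.32 log units; beyond the scatter) when pyridin-3-yl enters. Against the other difluorophenyl the change stays within the scatter, with a 1.9-fold higher number from compound 1 to compound 3 (0.29 log units; within the scatter), so the size of the effect depends on the comparison compound. No evidence on hand bears on the cause of this shift.

Unsubstituted phenyl would separate the ring nitrogen from the loss of both fluorines, and that separation remains open. Also open, as far as these compounds go, are pyridin-2-yl, pyridin-4-yl and a fluoropyridinyl group on this carbon.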